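Swapping the amide group: cyclohexyl to 2-methoxyphenyl

The compounds below may be only part of what the source reports. "The series", "measured", "known", "first", "only" and "open" are said of these compounds alone.

Compound 1, `O=C(Nc1ccc(Cl)cc1CN1C(=O)c2ccccc2C1=O)c1ccco1`: in an assay on CHO cells for positive allosteric modulation of metabotropic glutamate receptor 5 (Rattus norvegicus), read by FLIPR (on this read-out higher numbers stand for an effect only at larger amounts of compound and lower numbers for an effect already at smaller amounts), compound 1 gives < 1000 nM, which is a limit of the assay.
Compound 2, `O=C(Nc1ccc(Cl)cc1CN1C(=O)c2ccccc2C1=O)c1ncccn1`: in this assay compound 2 gives < 1000 nM, again a limit.
Compound 3, `O=C(Nc1ccc(Cl)cc1CN1C(=O)c2ccccc2C1=O)C1CCCCC1`: in this assay compound 3 gives < 1000 nM, also a limit.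

Compound 3 thus stands at the limit of < 1000 nM in this assay, at which 3 of the 3 values shown sit, so no number places it relative to the others. For the same reason the steps a step that the two limits leave unreadable from compound 1 to compound 2, a step that the two limits leave unreadable from compound 1 to compound 3 and a step that the two limits leave unreadable from compound 2 to compound 3 cannot be read in size or direction. Compound 4, `COc1ccccc1C(=O)Nc1ccc(Cl)cc1CN1C(=O)c2ccccc2C1=O`, differs from compound 3 in one place: 2-methoxyphenyl in place of cyclohexyl on a carbonyl carbon. Among the measured compounds shown here, no measured step gives a readable size for a change of this kind, so no direction beyond the scatter can be expected in this assay. Compound 4 is therefore estimated at 300 nM, with a range from 50 nM to 1500 nM, which means an expected step that the limit leaves unreadable from compound 3 to compound 4.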

Compound 4, half-maximal effective concentration: < 1000 nM
Compound 4: only a limit was reported (the forecaster's own chance of this, stated with the estimate: 70%); the middle value lies beyond the limit too.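

Compound 4 cannot be compared in size or direction with compound 1, compound 2 or compound 3, because all the values are limits, not numbers: the limit of < 1000 nM in this assay, at which 4 of the 4 values shown sit.

The compounds shown leave open how these four groups on the carbonyl carbon actually rank.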